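This account rests on a few compounds, and the source may have more. Where it says the series, first, only, none or still open, it means among the compounds named here.

Working notes on the series. Compound 1, `O=C1c2cc(C3CC3)nc(Oc3cccc(NS(=O)(=O)c4ccc(Cl)cc4)c3)c2C(=O)N1C1CC1`, in a functional assay on HEK293 cells for agonist activity at Glucose-dependent insulinotropic receptor (Homo sapiens), read by cAMP accumulation, with a stated time of 30 min (on this read-out lower numbers stand for smaller maximal responses and higher numbers for larger maximal responses), gives 99%. Compound 2, `COc1cc2c(c(Oc3cccc(NS(=O)(=O)c4ccc(Cl)cc4)c3)n1)C(=O)N(C1CC1)C2=O`, carries methoxy in place of cyclopropyl on an aromatic carbon, and in this assay compound 2 gives 97%. For the measured compounds named here, the single measured step, a number 2 percentage points lower from compound 1 to compound 2 (within the scatter), leaves the two numbers within the scatter of each other, so compound 2 stands beside compound 1 with no separation the assay can resolve. Compound 3, `Cc1cc2c(c(Oc3cccc(NS(=O)(=O)c4ccc(Cl)cc4)c3)n1)C(=O)N(C1CC1)C2=O`, is not yet measured; it differs from compound 2 by methyl in place of methoxy on an aromatic carbon. Going by the values given here, no measured step covers this pair of groups; the only step available altered the same place and stayed within the scatter, and both measured responses sit near the full reference response, leaving little room upward. No step beyond the scatter is therefore expected in this assay. Compound 3 is expected at 97%, between 85% and 105%, which means an expected step of no change at the digits printed from compound 2 to compound 3 (within the scatter).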

Compound 3, largest response reached (reported as efficacy), in percent of the reference or control that the assay uses: 111%
The estimate for compound 3 lay 14 percentage points below the measured number; the measured number lies above the stated range.
By their numbers in this assay, from the lowest: compounds 2 and 1 (each within the scatter of the next); then compound 3.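

In this assay methyl in place of methoxy gives a number 14 percentage points higher from compound 2 to compound 3 (beyond the scatter) and methyl in place of cyclopropyl gives a number 12 percentage points higher from compound 1 to compound 3 (beyond the scatter) at this aromatic carbon next to the ring nitrogen, so this position can separate groups on this read-out, which the step between methoxy and cyclopropyl alone did not show. Among the three groups shown here, methyl stands apart, while methoxy and cyclopropyl remain within the scatter of each other, and the maximal response on the shared core is not capped at the level those two reach. No measurement at hand accounts for this difference.

On these data alone, what an ethyl group, a chlorine atom or an amine would give at this place stays open. Also open, as far as these compounds go, is whether methyl gives a step of this kind when other parts of the shared core are changed.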